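This account rests on a few compounds, and the source may have more. Where it says the series, first, only, none or still open, it means among the compounds named here.

Compound 1 `CCOC(=O)/C=C/c1ccc(NC(=O)C2(NC(=O)c3ccc4c(C5CCCC5)c(-c5ncc(Cl)cn5)n(C)c4c3)CCC2)cc1OCC` in an ADME assay (intestine, Rattus norvegicus) for pharmacokinetics, using microsomes (on this read-out higher numbers stand for a longer-lived compound and lower numbers for a shorter-lived compound), gives > 5 h, a limit of the assay.
Compound 2 `CCOc1cc(NC(=O)C2(NC(=O)c3ccc4c(C5CCCC5)c(-c5ncc(Cl)cn5)n(C)c4c3)CCC2)ccc1/C=C/C(=O)OCC(C)C` gives > 5 h, again a limit.
Compound 3 `CCOc1cc(NC(=O)C2(NC(=O)c3ccc4c(C5CCCC5)c(-c5ncc(Cl)cn5)n(C)c4c3)CCC2)ccc1/C=C/C(=O)OCC(Cl)(Cl)Cl` gives > 5 h, again a limit.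

All three values shown for this series sit at the same limit (the limit of > 5 h in this assay, at which 3 of the 3 values shown sit), so compound 3 cannot be placed above or below compound 1 or compound 2 on the numbers shown. For the measured compounds named here, for the same reason the steps a step that the two limits leave unreadable from compound 1 to compound 2, a step that the two limits leave unreadable from compound 1 to compound 3 and a step that the two limits leave unreadable from compound 2 to compound 3 have no readable size; they tell only that each change at the saturated chain carbon bound to an oxygen next to a carbonyl group left the compound at the limit.

Compound 4 `CCOc1cc(NC(=O)C2(NC(=O)c3ccc4c(C5CCCC5)c(-c5ncc(Cl)cn5)n(C)c4c3)CCC2)ccc1/C=C/C(=O)OCC(=O)N1CCOCC1` differs from compound 3 by (morpholin-4-yl)carbonyl in place of trichloromethyl on a saturated chain carbon bound to an oxygen next to a carbonyl group. Going by the values given here, no measured step covers this change, and the three unreadable steps give no direction. Among the compounds with values here, since every variation at this position so far has stayed at the limit, compound 4 is expected to give 5 h in this assay, within 1.5 h to 10 h, because compound 3 gives > 5 h. The estimated step of a number no higher from compound 3 to compound 4 (the limit leaves the size open) is thus expected to lie within the scatter, with a fair chance that only a limit is reported.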

Compound 4, half-life: 1.27 h
Compound 4: the middle estimate sits 3.9-fold (0.60 log units) above what was measured; measured number below the stated range.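

In this assay, the place on a saturated chain carbon bound to an oxygen next to a carbonyl group now shows a readable change: (morpholin-4-yl)carbonyl in place of trichloromethyl gives an at least 3.9-fold lower number from compound 3 to compound 4 (0.59 log units; beyond the scatter), in place of isopropyl it gives an at least 3.9-fold lower number from compound 2 to compound 4 (0.59 log units; beyond the scatter), and in place of methyl it gives an at least 3.9-fold lower number from compound 1 to compound 4 (0.59 log units; beyond the scatter). The read-out at this place therefore does respond to the group it carries, and each of these steps is a minimum, not a full size. Compound 4 alone has left the limit, which still holds the other three compounds: the limit of > 5 h in this assay, at which 3 of the 4 values shown sit.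

As far as these compounds go, the steps among compound 1, compound 2 and compound 3 cannot be read, and their order remains unknown. It also remains open whether the morpholine ring or the carbonyl carries the change, with a carboxylic acid, a hydroxyl or a dimethylamide at this place not among the compounds shown.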